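Swapping the heptyl of compound 3 for an aryl amide

The source may report more compounds than this note shows. Statements on the series, on what has been measured and on what is new or still open speak of the compounds shown alone.

Three compounds share one core, differing only in the group on the triazole nitrogen. Compound 1 `CCOC(=O)C1=Cc2ccccc2OC1(OCc1cn(-c2cccc(OC)c2)nn1)C(F)(F)F` carries a 3-methoxyphenyl there. In a functional assay on HeLa cells (Homo sapiens) for inhibition, read by MTT assay, with a stated time of 24 h (a lower number here means a stronger inhibitor, a higher number a weaker inhibitor), compound 1 gives > 150000 nM, which is a limit of the assay rather than a number. Compound 2 `CCOC(=O)C1=Cc2ccccc2OC1(OCc1cn(CC(=O)Nc2ccc(C)cc2)nn1)C(F)(F)F` gives 67400 nM, so the step of an at least 2.2-fold lower number from compound 1 to compound 2 (0.34 log units; beyond the scatter) is readable. Compound 3 `CCCCCCCCn1cc(COC2(C(F)(F)F)Oc3ccccc3C=C2C(=O)OCC)nn1` carries an octyl chain; in this assay compound 3 gives > 150000 nM, again only a limit. Compound 3 therefore stands at the limit (the limit of > 150000 nM in this assay, at which 2 of the 3 values shown sit), and the step of an at least 2.2-fold higher number from compound 2 to compound 3 (0.34 log units; beyond the scatter) marks it as weaker than compound 2, while the step that the two limits leave unreadable from compound 1 to compound 3 cannot be read.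

Compound 4 `CCOC(=O)C1=Cc2ccccc2OC1(OCc1cn(CC(=O)Nc2ccc(OC)cc2)nn1)C(F)(F)F` is not yet measured. It differs from compound 3 by (4-methoxyphenyl)carbamoyl in place of heptyl on a saturated chain carbon bound to an aromatic nitrogen. This change mirrors the step from compound 2 to compound 3 reversed, with a methoxy instead of a methyl on the aryl ring. The step from compound 2 to compound 3 bears directly on it and was at least modest. Compound 4 is therefore expected to fall back toward compound 2, a step of an at least 2.1-fold lower number from compound 3 to compound 4 (0.33 log units; beyond the scatter) in this assay. Compound 4 is estimated at 70000 nM, within 30000 nM to 160000 nM.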

Compound 4, half-maximal inhibitory concentration: 31900 nM
Compound 4: middle estimate off by 2.2-fold (0.34 log units), on the high side; the range from low to high includes it.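

In this assay, a second aryl amide now moves off the limit, with an at least 4.7-fold lower number from compound 3 to compound 4 (0.67 log units; beyond the scatter) and an at least 4.7-fold lower number from compound 1 to compound 4 (0.67 log units; beyond the scatter), and the gain seen with compound 2 therefore does not depend on the methyl on the aryl ring. The group on that ring also counts: methoxy in place of methyl gives a 2.1-fold lower number from compound 2 to compound 4 (0.32 log units; beyond the scatter), the only step among these compounds with a measured number at both ends. The two steps from the compounds that sit at the limit give only a minimum size: the limit of > 150000 nM in this assay, at which 2 of the 4 values shown sit.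

With only methyl and methoxy shown on the aryl ring of the amide, it remains open how a chlorine, a carboxylic acid or a dimethylamino group at that place would read. As far as these compounds go, it also remains open whether the amide hydrogen matters, which a nitrogen-methyl amide would test.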